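A few compounds are considered here, and "the series" means these few. Any claim that something is new, unique, unknown or untested is made for them only; others in the source may bear on it.

Measured so far in a functional assay on HCT-116 cells (Homo sapiens) for antiproliferative activity, read by MTT assay, with a stated time of 72 h; on this read-out lower numbers stand for stronger inhibition and higher numbers for weaker inhibition:
Compound 1 `Nc1nc(N)c2cc(CSC(=S)N3CCN(C4CCCCC4)CC3)ccc2n1`: 8400 nM
Compound 2 `Nc1nc(N)c2cc(CSC(=S)N3CCN(c4ccc(Cl)c(Cl)c4)CC3)ccc2n1`: 6680 nM

Only these two values are available, and they lie within the scatter of each other, so compound 2 cannot be separated from compound 1. Compound 3 `Nc1nc(N)c2cc(CSC(=S)N3CCN(c4ccc(F)cc4F)CC3)ccc2n1` keeps everything in compound 2 except one group: 2,4-difluorophenyl in place of 3,4-dichlorophenyl on an amine nitrogen in a ring. In words, 2,4-difluorophenyl stands in place of 3,4-dichlorophenyl on an amine nitrogen in a ring.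

Going by the values given here, only one measured step bears on this change, as it touches the same place: a 1.3-fold lower number from compound 1 to compound 2 (0.10 log units; within the scatter). There, 3,4-dichlorophenyl replaced cyclohexyl, and the value did not move beyond the scatter. This is thin evidence, since a single step says nothing directly about a swap between two substituted phenyl groups. Even so, it gives no reason to expect a large effect, so no step beyond the scatter is expected in this assay, in either direction. The expected outcome is a 1.0-fold higher number from compound 2 to compound 3 (0.02 log units; within the scatter). The estimated value for compound 3 is 7000 nM, with an expected range of 3500 nM to 14000 nM.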

Compound 3, half-maximal inhibitory concentration: 5150 nM
Estimate against measurement, compound 3: 1.4-fold (0.13 log units) above, and the stated range covers the measured number.
By their numbers in this assay, from the lowest: compounds 3, 2 and 1 (each within the scatter of the next).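

In this assay, the comparison at this amine nitrogen now includes two substituted phenyl groups, and 2,4-difluorophenyl in place of 3,4-dichlorophenyl gives a 1.3-fold lower number from compound 2 to compound 3 (0.11 log units; within the scatter). The direct comparison of 2,4-difluorophenyl with cyclohexyl gives a 1.6-fold lower number from compound 1 to compound 3 (0.21 log units; within the scatter), so cyclohexyl and both halogen-bearing phenyl groups cannot be told apart at this position in this assay, and neither the change from chlorine to fluorine with its new placement on the ring nor the change from cyclohexyl to either phenyl group gives a separable result. No independent measurement bears on this result.

All three groups at this position are six-membered carbon rings, which leaves open how the antiproliferative read-out would respond to a different kind of group there, such as a carboxylic acid, a basic amine on a longer chain, or a small methyl. All three compounds also share the same core and the same sulfur-containing link to the ring bearing this group, so these compounds cannot show how much those parts contribute to the values.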